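Swapping a benzofuran for cyclopropyl on the piperidine nitrogen

The source may hold more compounds than are shown below. What is called first, only, known or untested is meant among the compounds shown, and "the series" means these compounds.

Measured compounds:
compound 1 `O=C(c1cc2ccccc2o1)N1CCC(NCCSC(c2ccc(F)cc2)c2ccc(F)cc2)CC1` — 115 nM
compound 2 `Fc1ccc(C(SCCNC2CCN(Cc3cc4ccccc4o3)CC2)c2ccc(F)cc2)cc1` — 120 nM

In an assay on membranes from striatum (strain Sprague-Dawley) for displacement of a labelled ligand from sodium-dependent dopamine transporter (Rattus norvegicus), read by scintillation counting, with a stated time of 120 min (on this read-out higher numbers stand for weaker inhibition and lower numbers for stronger inhibition), compound 2 gives 120 nM, the higher of the two numbers measured, with compound 1 nearest to it. Within the data shown here, the only measured step, a 1.0-fold higher number from compound 1 to compound 2 (0.02 log units; within the scatter), exchanges one linkage on the ring nitrogen for another and leaves the number essentially unchanged.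

Compound 3 `Fc1ccc(C(SCCNC2CCN(CC3CC3)CC2)c2ccc(F)cc2)cc1` is not yet measured. It differs from compound 2 by cyclopropyl in place of 1-benzofuran-2-yl on a saturated chain carbon bound to an amine nitrogen in a ring. Among the measured compounds shown here, this change is of a different kind from the one between compound 1 and compound 2: there, the benzofuran stayed and only its link to the nitrogen changed, whereas here the benzofuran itself is removed and a much smaller group takes its place. For the measured compounds named here, no measured step covers such a removal, so the expectation rests on loose analogy and carries wide uncertainty. Compound 3 is expected to show a somewhat weaker inhibition, an estimated step of a 2.5-fold higher number from compound 2 to compound 3 (0.40 log units; beyond the scatter). The estimated value for compound 3 in this assay is 300 nM, within a range from 80 nM to 1200 nM.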

Compound 3, inhibition constant: 407 nM
The estimate for compound 3 lay 1.4-fold (0.13 log units) below the measured number; the measured number falls inside the stated range.
By their numbers in this assay, from the lowest: compounds 1 and 2 (each within the scatter of the next); then compound 3.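

Compounds 1 and 2 showed that the link to the amine nitrogen in a ring could change without moving the number; this result shows that the group carried on that link does matter. In this assay, cyclopropyl in place of 1-benzofuran-2-yl gives a 3.4-fold higher number from compound 2 to compound 3 (0.53 log units; beyond the scatter). The comparison with the carbonyl-linked compound points the same way, with a 3.5-fold higher number from compound 1 to compound 3 (0.55 log units; beyond the scatter), yet both steps are modest, so the benzofuran is not essential for a measurable number in this series.

No measurement at hand says why the number changes with this swap. From the compounds shown here alone, whether the size of the group or its aromatic rings count stays open, and a phenyl or a cyclohexyl group on the same saturated chain carbon would help tell the two apart.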